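This account rests on a few compounds, and the source may have more. Where it says the series, first, only, none or still open, it means among the compounds named here.

Three close relatives share one core. Compound 2 `C=CCn1c(=O)/c(=C\c2ccccc2OC)[nH]c(=O)/c1=C\c1ccccc1OC` is the reference point. Among the compounds with values here, in a functional assay on NCI-H1975 cells (Homo sapiens) for cytotoxicity, read by CCK-8 assay, with a stated time of 72 h (a higher number here means a weaker inhibitor, a lower number a stronger inhibitor), compound 2 gives 21500 nM, and this is the only number available in the set. The one other measured entry, compound 1 `C=CCn1c(=O)/c(=C\c2cc(Br)ccc2F)[nH]c(=O)/c1=C\c1ccccc1OC`, was recorded in this assay as "not active" (no number reported), with no figure attached. Compound 3 `C=CCn1c(=O)/c(=C\c2cccc(Br)c2)[nH]c(=O)/c1=C\c1ccccc1OC` has not yet been tested. It differs from compound 2 in a single place: 3-bromophenyl in place of 2-methoxyphenyl on a double-bonded chain carbon bound to an aromatic carbon. Within the data shown here, no measured pair in this set shows the effect of such a swap, so the expectation rests on thin ground. Compound 1, the only other relative that carries a bromine, gave "not active" (no number reported), which hints at a weaker rather than a stronger inhibitor. The expected step is a 1.9-fold higher number from compound 2 to compound 3 (0.27 log units; within the scatter), a loss somewhat beyond the scatter. Compound 3 is estimated at 40000 nM, with a likely range from 12000 nM to 130000 nM, and a real chance that no number is returned at all.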

Compound 3, half-maximal inhibitory concentration: "not active" (no number reported)
The entry for compound 3 holds no number; there is nothing to compare the estimate with.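

Within the data shown here, compound 3 returned no number, so no step from compound 2 to compound 3 can be read. The compounds shown leave open how far 3-bromophenyl in place of 2-methoxyphenyl shifts cytotoxic strength, if at all. Nothing here offers an explanation for this result.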